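Hydroxyazetidine replaces a sulfamoylamino group on the side chain

This account rests on a few compounds, and the source may have more. Where it says the series, first, only, none or still open, it means among the compounds named here.

Compound 3 `CN(C)S(=O)(=O)NC[C@@H]1CCCc2cc(S(=O)(=O)c3cccc(F)c3)ccc21` gives 2 nM in an assay on isolated protein for displacement of a labelled ligand from 5-hydroxytryptamine receptor 6 (Homo sapiens); a lower number here means a stronger inhibitor, a higher number a weaker inhibitor. Among the three measured compounds it holds the second highest number: compound 2 `Cn1ccc(S(=O)(=O)c2ccc3c(c2)CCC[C@H]3CN)c1` shows 7.94 nM, while compound 1 `CNCC1CCCc2cc(S(=O)(=O)c3ccccc3)ccc21` shows 0.316 nM, and both of these gaps to compound 3 lie beyond the usual scatter. Compound 4 `O=S(=O)(c1cccc(F)c1)c1ccc2c(c1)CCC[C@H]2CN1CC(O)C1` has not yet been measured in this assay. It differs from compound 3 in one place: 3-hydroxyazetidin-1-yl in place of (dimethylsulfamoyl)amino on a saturated chain carbon bound to a saturated ring carbon. No measured pair in this set isolates that change, so the direction of the step rests on the compounds shown alone, and their other differences are not confined to this position. Compound 4 is expected to stay close to compound 3, with the step of a 1.3-fold lower number from compound 3 to compound 4 (0.12 log units; within the scatter) estimated as a modest move toward a lower number rather than a shift beyond the scatter in either direction. On that basis compound 4 is estimated at 1.5 nM in this assay, within a range from 0.4 nM to 6 nM.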

Compound 4, inhibition constant: 0.1 nM
Compound 4: the middle estimate sits 15-fold (1.18 log units) above what was measured; measured number below the stated range.
By their numbers in this assay, from the lowest: compound 4; then compound 1; then compound 3; then compound 2.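

In this assay, within the data shown here, this place, on a saturated chain carbon bound to a saturated ring carbon, proves sensitive to the group it carries: the change gives a 20-fold lower number from compound 3 to compound 4 (1.30 log units; beyond the scatter), the first step in this set that isolates a single change. It also shows that (dimethylsulfamoyl)amino is not required here for a low number, as 3-hydroxyazetidin-1-yl takes its place with no sulfur and with one four-membered non-aromatic ring, while the counts of hydrogen-bond donors and acceptors stay the same and neither group has a net charge. Nothing available explains the size of this step.

The compounds shown leave open whether the step follows from the four-membered ring or from its hydroxyl, which an unsubstituted azetidine or a methoxy group in place of the hydroxyl would separate. They also leave open whether the change would carry over to the core of compound 1, which lacks the fluorine.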